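Ether variation on the shared core: outlook for compound 3

The source may report more compounds than this note shows. Statements on the series, on what has been measured and on what is new or still open speak of the compounds shown alone.

Compound 1 `CC(=O)OC1=CC(=O)C2=C(C1=O)[C@]13CCC[C@](C)(C(=O)OC1)[C@@H]3C=C2` gives 99.7% in an ADME assay on Vero cells (Chlorocebus sabaeus) for cytotoxicity, read by microscopy, with a stated time of 24 h, tested at 2 ug/mL; a higher number here means a weaker effect of the compound at the concentration tested, a lower number a stronger effect. Compound 2 `C[C@@]12CCC[C@]3(COC1=O)C1=C(C=C[C@H]32)C(=O)C=C(O[Si](C)(C)C)C1=O` gives 99.6% in this assay. Among the measured compounds shown here, the single measured step is a number 0.1 percentage points lower from compound 1 to compound 2 (within the scatter): a group of 4 heavy atoms (3 carbon, 1 silicon) in place of a group of 3 heavy atoms (2 carbon, 1 oxygen) on the oxygen on the unsaturated carbon left the read-out unchanged. Compound 2 thus sits together with compound 1 at the top end of the scale, the gap between them within the scatter.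

Compound 3 `C=CCOC1=CC(=O)C2=C(C1=O)[C@]13CCC[C@](C)(C(=O)OC1)[C@@H]3C=C2` differs from compound 2 by a group of 3 heavy atoms (3 carbon; no ring) in place of a group of 4 heavy atoms (3 carbon, 1 silicon; no ring), on an oxygen on an unsaturated carbon. For the measured compounds named here, the one step that bears on this change is the exchange at the same oxygen from compound 1 to compound 2, which was within the scatter. With both measured substituents at this position giving essentially full values, no step beyond the scatter is expected in this assay. Compound 3 is expected at 99.5%, within 95% to 100%. The expected step is a number 0.1 percentage points lower from compound 2 to compound 3 (within the scatter), within the scatter.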

Compound 3, a percentage reported as activity, at one concentration (the size of the read-out at that concentration, not a potency): 99.6%
Beside the measured number, compound 3's estimate is 0.1 percentage points below it; measured number inside the range.
By their numbers in this assay, from the lowest: compounds 2, 3 and 1 (each within the scatter of the next).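

Allyl, with its double bond outside aromatic rings, brings a third type of group to the oxygen on the unsaturated carbon, and in this assay its exchange for the silicon-bearing group gives no change at the digits printed from compound 2 to compound 3 (within the scatter). Set against acetyl, the same group gives a number 0.1 percentage points lower from compound 1 to compound 3 (within the scatter), so the comparison now covers all three pairs at this oxygen, and acetyl, the silicon-bearing group and allyl lie within the scatter of one another at the top end of the scale, where the effect at the tested concentration is weak. Nothing at hand accounts for this flat result.

The compounds shown leave open whether an amine on a short chain, a carboxylic acid or a longer alkyl chain on this oxygen would move the number in this assay beyond the scatter, since the three groups here have no hydrogen-bond donors or acceptors and no net charge. Also open, on these data alone, is whether the same flat picture would hold at another concentration, or for a change made elsewhere on the shared core.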